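The source may report more compounds than this note shows. Statements on the series, on what has been measured and on what is new or still open speak of the compounds shown alone.

Measured in an ADME assay on HEK-293T cells (Homo sapiens) for inhibition, read by CCK-8 assay, with a stated time of 48 h, tested at 20 uM; a lower number here means less inhibition of growth, a higher number more inhibition of growth at the concentration tested:
compound 1 `Cc1ccc(S(=O)(=O)Oc2cccc(/C=C(\C#N)C(=O)Nc3nnc(-c4cccs4)s3)c2)cc1`: 43%
compound 2 `N#C/C(=C\c1cccc(OS(=O)(=O)c2cccs2)c1)C(=O)Nc1nnc(-c2cccs2)s1`: 50%
compound 3 `N#C/C(=C\c1cccc(NS(=O)(=O)c2ccc(F)cc2)c1)C(=O)Nc1nnc(-c2cccs2)s1`: 29%

Compound 3 stands lowest of the three at 29%. The two steps leading to it are both modest: a number 14 percentage points lower from compound 1 to compound 3 (beyond the scatter) and a number 21 percentage points lower from compound 2 to compound 3 (beyond the scatter). Each of them also exchanges the sulfonyl-oxy group for a sulfonyl-amino group, a change that compound 4 does not make.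

Compound 4 `COc1ccc(S(=O)(=O)Nc2cccc(/C=C(\C#N)C(=O)Nc3nnc(-c4cccs4)s3)c2)cc1` carries methoxy in place of fluoro on an aromatic carbon, para to a large group (methoxy in place of fluoro on an aromatic carbon). Going by the values given here, no measured step makes this exchange. Among the compounds with values here, the closest precedent is a change of only the ring on a sulfonyl sulfur, a number 7 percentage points higher from compound 1 to compound 2 (within the scatter). On that single precedent, no step beyond the scatter is expected in this assay. The expected step is small and upward, a number 3 percentage points higher from compound 3 to compound 4 (within the scatter). The estimate for compound 4 is 32%, with an expected range of 18% to 47%.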

Compound 4, percent growth inhibition at one concentration: 21%
The estimate for compound 4 lay 11 percentage points above the measured number; measured number inside the range.
By their numbers in this assay, from the lowest: compounds 4 and 3 (each within the scatter of the next); then compounds 1 and 2 (each within the scatter of the next).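

Methoxy in place of fluoro, on an aromatic carbon para to a large group, gives in this assay only a small step: a number 8 percentage points lower from compound 3 to compound 4 (within the scatter). The earlier compounds shown here showed changes of the ring on a sulfonyl sulfur and of the sulfonyl-oxy group for the sulfonyl-amino group, whereas this pair shows that 4-fluorophenyl to 4-methoxyphenyl, with the sulfonyl-amino group kept, does not separate the two compounds in this growth read-out. No measurement at hand bears on the reason for this result.

On these data alone, whether the position stays this flat with an amine or a carboxylic acid there remains open. Going by these compounds alone, the exchange of fluoro for methoxy is also seen only with the sulfonyl-amino group, so its size with the sulfonyl-oxy group remains open too.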